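This account rests on a few compounds, and the source may have more. Where it says the series, first, only, none or still open, it means among the compounds named here.

Measured in an ADME assay on the whole organism (Mus musculus, strain ICR), read by LC-MS, with a stated time of 24 h, at a dose of 50 mg/kg by the oral route; a lower number here means that the compound disappears faster, a higher number that the compound lasts longer:
compound 1 `Cc1nc(N[C@H](C)c2cccc(C(F)F)c2F)c2cc3c(cc2n1)OCC[C@H]1CN(C(=O)C2COC2)CCN31`: 1.7 h
compound 2 `Cc1nc(N[C@H](C)c2cccc(C(F)F)c2F)c2cc3c(cc2n1)OCC[C@H]1CN(C(=O)c2cccnc2)CCN31`: 1.78 h
compound 3 `Cc1nc(N[C@H](C)c2cccc(C(F)F)c2F)c2cc3c(cc2n1)OCC[C@H]1CN(C)CCN31`: 9.58 h

Compound 3, at 9.58 h, stands highest of the three in this assay, and its gaps to the other two lie beyond the scatter. Compound 4 `Cc1nc(N[C@H](C)c2cccc(C(F)F)c2F)c2cc3c(cc2n1)OCC[C@H]1CN(CC2COC2)CCN31` differs from it by one change, (oxetan-3-yl in place of hydrogen on a saturated chain carbon bound to an amine nitrogen in a ring). In words, oxetan-3-yl takes the place of hydrogen on a saturated chain carbon bound to an amine nitrogen in a ring, so that methyl becomes (oxetan-3-yl)methyl.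

Among the measured compounds shown here, no measured step makes this exact change. The closest evidence concerns the same nitrogen, where a 5.6-fold higher number from compound 1 to compound 3 (0.75 log units; beyond the scatter) and a 5.4-fold higher number from compound 2 to compound 3 (0.73 log units; beyond the scatter) are both modest and beyond the scatter. In each, methyl replaces a group joined through a carbonyl. By contrast, a 1.0-fold higher number from compound 1 to compound 2 (0.02 log units; within the scatter) lies within the scatter. Compound 4 has no carbonyl on that nitrogen, like compound 3, yet it carries the oxetan-3-yl that compound 1 holds on its carbonyl at 1.7 h. The data therefore point only weakly to some loss. The expected step is a 1.7-fold lower number from compound 3 to compound 4 (0.24 log units; within the scatter), towards a lower number and of a size that would stay within the scatter. For compound 4 the estimated value is 5.5 h, expected to fall between 2.5 h and 11 h.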

Compound 4, mean residence time: 7.64 h
Compound 4: the middle estimate sits 1.4-fold (0.14 log units) below what was measured, within the range that was stated.
By their numbers in this assay, from the lowest: compounds 1 and 2 (each within the scatter of the next); then compounds 4 and 3 (each within the scatter of the next).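

In this assay, among the compounds shown here, the step from methyl to (oxetan-3-yl)methyl on the amine nitrogen in a ring gives a 1.3-fold lower number from compound 3 to compound 4 (0.10 log units; within the scatter) and so cannot be told apart from repeat measurement; this is the first sign that the position accepts an oxetan-3-yl on the saturated chain carbon without a change beyond the scatter. The oxetan-3-yl alone therefore does not bring the low number seen with the carbonyl-linked groups: replacing the carbonyl link with a saturated carbon gives a 4.5-fold higher number from compound 1 to compound 4 (0.65 log units; beyond the scatter) with the same oxetan-3-yl kept, and the change from the pyridine amide gives a 4.3-fold higher number from compound 2 to compound 4 (0.63 log units; beyond the scatter) in a similar modest size, so among these four compounds the two carbonyl-bearing ones sit lowest, with no compound against that pattern. Nothing measured here accounts for these steps, and the reason for them stays unknown.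

The compounds shown leave open whether a dimethylamino group, a carboxylic acid or a longer chain on that same saturated chain carbon would keep the number at this level. They also leave open how a pyridin-3-yl would behave there, since it appears only on a carbonyl.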